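The source may report more compounds than this note shows. Statements on the series, on what has been measured and on what is new or still open speak of the compounds shown alone.

Measured so far:
- Compound 1 `C=C(Br)C(=O)Nc1ccc(/C=C/C(=O)c2ccc(Cl)cc2)cc1`: 1100 nM
- Compound 2 `C=C(Br)C(=O)Nc1ccc(/C=C/C(=O)c2ccc(C)cc2)cc1`: 1900 nM

Both compounds were tested in a functional assay on L1210 cells (Mus musculus) for antiproliferative activity, with a stated time of 48 h; a higher number here means a weaker inhibitor, a lower number a stronger inhibitor. Among the compounds with values here, with only two numbers available, compound 2 can be placed in just one way: it lies within the usual scatter of compound 1, so the two cannot be told apart.

The next compound is compound 3 `C=C(Br)C(=O)Nc1ccc(/C=C/C(=O)c2ccc(OCC)cc2)cc1`, which keeps the shared core and alters one substituent. The change from compound 2 is ethoxy in place of methyl on an aromatic carbon. In words, ethoxy replaces methyl on an aromatic carbon, para to a large group.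

Within the data shown here, only one measured step bears on this: a 1.7-fold higher number from compound 1 to compound 2 (0.24 log units; within the scatter), with methyl in place of chloro on an aromatic carbon. Among the measured compounds shown here, that single swap gives a weak guide, and no measured compound carries ethoxy, so the uncertainty is wide. Even so, nothing measured points to a change beyond the scatter in this assay, in either direction.

The estimated step is a 1.1-fold lower number from compound 2 to compound 3 (0.05 log units; within the scatter), which amounts to no expected change beyond the scatter. For compound 3 the expected value is 1700 nM, with an estimated range of 700 nM to 4000 nM.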

Compound 3, half-maximal inhibitory concentration: 240 nM
The estimate for compound 3 lay 7.1-fold (0.85 log units) above the measured number; measured number outside the range, below it.
By their numbers in this assay, from the lowest: compound 3; then compounds 1 and 2 (each within the scatter of the next).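

In this assay, the group on the aromatic carbon para to a large group turns out to matter: ethoxy in place of methyl gives a 7.9-fold lower number from compound 2 to compound 3 (0.90 log units; beyond the scatter) and ethoxy in place of chloro gives a 4.6-fold lower number from compound 1 to compound 3 (0.66 log units; beyond the scatter) at the same place. Within the data shown here, the earlier pair, chloro and methyl, could not be told apart, so these steps are the first sign that a change here can move the number beyond the scatter, in this case towards a stronger inhibitor. Compared with methyl, ethoxy brings 3 heavy atoms instead of 1, including an oxygen, and 1 hydrogen-bond acceptor instead of 0, but nothing available shows which of these differences, if any, accounts for the drop.

The three compounds leave open whether the oxygen or the extra carbon of ethoxy goes with the lower number, a question that methoxy or a plain propyl group at this place could help to separate. They also leave open whether a longer chain such as butoxy, or an amine, would lower the number further or raise it again.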